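The source may report more compounds than this note shows. Statements on the series, on what has been measured and on what is new or still open speak of the compounds shown alone.

Measured so far in an in vitro assay on 293-EBNA cells for binding affinity to corticotropin-releasing factor receptor 1 (Homo sapiens); on this read-out lower numbers stand for stronger inhibition and higher numbers for weaker inhibition:
Compound 1 `CCCCN(CC)c1nc(C)nc2c1nnn2-c1c(C)cc(C)cc1C` gives 27.5 nM.
Compound 2 `CCC(CC)Nc1nc(C)nc2c1nnn2-c1c(C)cc(C)cc1C` gives 5.7 nM.
Compound 3 `CCN(CC)c1nc(C)nc2c1nnn2-c1ccc(C(C)C)cc1Br` gives 25.3 nM.

In this assay compound 3 stands second highest of these three numbers, close to compound 1 and well apart from compound 2. Compound 4 `CCC(CO)Nc1nc(C)nc2c1nnn2-c1ccc(C(C)C)cc1Br` has not been measured yet and differs from compound 3 in one place: (1-(hydroxymethyl)propyl)amino in place of diethylamino on an aromatic carbon. For the measured compounds named here, one measured step bears on this change: a 4.8-fold lower number from compound 1 to compound 2 (0.68 log units; beyond the scatter), where butyl(ethyl)amino gave way to (pentan-3-yl)amino. Going by the values given here, the change to compound 4 is of the same kind, but the entering group also carries a hydroxymethyl, which no measured compound shows. A step in the same direction, somewhat smaller, is therefore expected in this assay: a 3.2-fold lower number from compound 3 to compound 4 (0.50 log units; beyond the scatter). Compound 4 is expected to give 8 nM, within a range from 3 nM to 25 nM.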

Compound 4, inhibition constant: 25.3 nM
For compound 4 the middle estimate is 3.2-fold (0.50 log units) below the measured one; measured number above the stated range.
By their numbers in this assay, from the lowest: compound 2; then compounds 3, 4 and 1 (each within the scatter of the next).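

In this assay the change to (1-(hydroxymethyl)propyl)amino gives no change at the digits printed from compound 3 to compound 4 (within the scatter), so this position accepts a branched amino group bearing a hydroxymethyl with no shift in the number. The drop seen in a 4.8-fold lower number from compound 1 to compound 2 (0.68 log units; beyond the scatter) therefore does not carry over to this change. No measurement shown explains the difference.

Still open, as far as these compounds go, is whether the hydroxymethyl or the rest of the molecule sets this outcome. Plain (pentan-3-yl)amino, or an amine in place of the hydroxyl, with the rest of compound 4 unchanged, would help to separate the two.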